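Adding a Methoxy Group in a Weakly Active Series

The compounds below may be only part of what the source reports. "The series", "measured", "known", "first", "only" and "open" are said of these compounds alone.

The study compares four compounds that share a core and differ in the substitution of their aromatic rings. Compound 1 `COc1cc(C2CC(c3ccccc3)=NN2C(=O)OCc2ccccc2)cc(OC)c1OC` carries an unsubstituted phenyl on one side. Compound 2 `COc1ccc(C2=NN(C(=O)OCc3ccccc3)C(c3cc(OC)c(OC)c(OC)c3)C2)cc1` differs from it by methoxy in place of hydrogen on an aromatic carbon. Compound 3 `COC(=O)N1N=C(c2ccccc2)CC1c1ccc(OC)cc1` is a smaller analogue; the difference between its core and the core of compound 1 is not broken down here. Compound 4 `COC(=O)N1N=C(c2ccccc2)CC1c1ccc(OC)c(OC)c1`, not yet measured, differs from compound 3 by methoxy in place of hydrogen on an aromatic carbon. The two changes are the same kind of change, though the place is not the same: in compound 2 the new methoxy sits para to a large group, whereas in compound 4 it sits ortho to a methoxy group and meta to a large group.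

In a functional assay on HepG2 cells (Homo sapiens) for antiproliferative activity, read by MTT assay, with a stated time of 48 h (on this read-out higher numbers stand for weaker inhibition of growth and lower numbers for stronger inhibition of growth), compound 1 gives only a limit, > 10000 nM. Compound 2 likewise reaches only a limit in this assay, > 10000 nM. The step that the two limits leave unreadable from compound 1 to compound 2 therefore cannot be read. Going by the values given here, compound 3 is the only one with a number in this assay, 12000 nM, and it lies close to the limit of > 10000 nM in this assay, at which 2 of the 3 values shown sit.

The step from compound 1 to compound 2 sits at the limit of > 10000 nM in this assay, at which 2 of the 3 values shown sit, and offers no size to lean on. The step of a 1.3-fold higher number from compound 3 to compound 4 (0.10 log units; within the scatter) is therefore expected to be small, resting on compound 3 and its value 12000 nM alone. Compound 4 is expected to give 15000 nM in this assay, with a likely range from 5000 nM to 40000 nM.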

Compound 4, concentration for 50% growth inhibition: 9150 nM
For compound 4 the middle estimate is 1.6-fold (0.21 log units) above the measured one; the range from low to high includes it.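

In this assay, methoxy in place of hydrogen on an aromatic carbon gives a 1.3-fold lower number from compound 3 to compound 4 (0.12 log units; within the scatter), so on the core of compound 3 this change, placed ortho to a methoxy group and meta to a large group, produces no step beyond the usual scatter of repeated measurements. The same kind of change on the core of compound 1 cannot be read, because compound 1 and compound 2 each give a limit and not a number: the limit of > 10000 nM in this assay, at which 2 of the 4 values shown sit. The series therefore offers a single readable step, which does not show that the change carries from one core to another, either as a small step or as a large one, and the new methoxy does not sit in the same place in compound 2 as in compound 4.

The compounds shown leave open whether an amine or a carboxylic acid on that same aromatic carbon of the core of compound 3 would give a step beyond the scatter in this assay. They also leave open whether a longer chain in place of the new methoxy would do so, and how compound 1 and compound 2 stand against each other.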